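Notes on the aryl group at the ring nitrogen

A few compounds are considered here, and "the series" means these few. Any claim that something is new, unique, unknown or untested is made for them only; others in the source may bear on it.

Within the data shown here, in a functional assay on A549 cells (Homo sapiens) for antiproliferative activity, read by MTT assay, with a stated time of 72 h (on this read-out higher numbers stand for weaker inhibition and lower numbers for stronger inhibition), compound 3 `O=C(Nc1ccc(Oc2ccnc3[nH]ccc23)c(F)c1)c1cc2cccnc2n(-c2ccc(F)cc2)c1=O` gives 62 nM, the lowest of the three numbers so far; compound 2 `O=C(Nc1ccc(Oc2ccnc3[nH]ccc23)cc1)c1cc2cccnc2n(-c2ccc(F)cc2)c1=O` gives 210 nM and compound 1 `O=C(Nc1ccc(Oc2ccnc3[nH]ccc23)cc1)c1cc2cccnc2n(-c2ccccc2)c1=O` gives 360 nM. Compound 4 `O=C(Nc1ccc(Oc2ccnc3[nH]ccc23)c(F)c1)c1cc2cccnc2n(-c2ccc(Br)cc2F)c1=O` is not yet measured and carries 4-bromo-2-fluorophenyl in place of 4-fluorophenyl on an aromatic nitrogen. Among the measured compounds shown here, the only measured step that touches this group is a 1.7-fold lower number from compound 1 to compound 2 (0.23 log units; within the scatter), which stayed within the scatter; the step of a 3.4-fold lower number from compound 2 to compound 3 (0.53 log units; beyond the scatter) concerns a fluoro that compound 4 keeps unchanged. For the measured compounds named here, no measured step covers bromine or a second fluorine on this ring, so no move beyond the scatter is expected, and the estimated step is a 1.1-fold lower number from compound 3 to compound 4 (0.05 log units; within the scatter). Compound 4 is therefore estimated at 55 nM, expected between 15 nM and 200 nM.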

Compound 4, half-maximal inhibitory concentration: 460 nM
Estimate against measurement, compound 4: 8.4-fold (0.92 log units) below; measured number outside the range, above it.
By their numbers in this assay, from the lowest: compound 3; then compounds 2, 1 and 4 (each within the scatter of the next, the first and the last beyond it).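

In this assay, the aryl group on the ring nitrogen proves sensitive to substitution: replacing 4-fluorophenyl with 4-bromo-2-fluorophenyl gives a 7.4-fold higher number from compound 3 to compound 4 (0.87 log units; beyond the scatter), whereas the earlier change at this position, a 1.7-fold lower number from compound 1 to compound 2 (0.23 log units; within the scatter), stayed within the scatter. This step is a clear loss, so the position does not accept every halogen change. No data given here explain the loss.

Bromine and the second fluorine enter together, so their separate contributions stay open. As far as these compounds go, how an amine or a methoxy group would behave on this ring also remains open.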